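Freeing the Aromatic Oxygen of Compound 2

This account rests on a few compounds, and the source may have more. Where it says the series, first, only, none or still open, it means among the compounds named here.

In a toxicity assay on cells (Cricetulus griseus) for cytotoxicity, read by MTT assay, with a stated time of 72 h (a higher number here means a weaker inhibitor, a lower number a stronger inhibitor), compound 1 `Cc1c(C)c2c(c(C)c1OC(=O)CCC(=O)NC1CC(C)(C)N([O])C(C)(C)C1)CC[C@@](C)(CCC[C@H](C)CCC[C@H](C)CCCC(C)C)O2` gives > 300000 nM as a limit of the assay and not a number. Compound 2 `Cc1c(C)c2c(c(C)c1OC(=O)CCC(=O)O)CCC(C)(C(=O)NC1CC(C)(C)N([O])C(C)(C)C1)O2` gives > 300000 nM as a limit too. Compound 2 thus stands at the limit of > 300000 nM in this assay, at which 2 of the 2 values shown sit, and offers no number to step from. Compound 3 `Cc1c(C)c2c(c(C)c1O)CCC(C)(C(=O)NC1CC(C)(C)N([O])C(C)(C)C1)O2` follows through hydrogen in place of (2-carboxyethyl)carbonyl on an oxygen on an aromatic ring as its change, with hydrogen in place of (2-carboxyethyl)carbonyl on an oxygen on an aromatic ring. Among the measured compounds shown here, no measured step guides this change. In this assay a small move toward a lower number, or none beyond the scatter, is expected, and the estimated step is an at least 1.2-fold lower number from compound 2 to compound 3 (0.07 log units; that floor lies within the scatter) in size. Compound 3 is expected at 250000 nM with an estimated range of 80000 nM to 400000 nM here.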

Compound 3, half-maximal inhibitory concentration: 186000 nM
For compound 3 the middle estimate is 1.3-fold (0.13 log units) above the measured one; low and high end bracket the measured number.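

With the (2-carboxyethyl)carbonyl gone from the oxygen on the aromatic ring, the series gains its first actual number in this assay, where compound 3 gives 186000 nM. The change reads as an at least 1.6-fold lower number from compound 2 to compound 3 (0.20 log units; that floor lies within the scatter), so only a floor on its size can be stated. The starting point of this step is a limit of the assay and not a number: the limit of > 300000 nM in this assay, at which 2 of the 3 values shown sit.

On these data alone, the true size of the step remains open. So does how a methyl ether, an acetyl ester or a longer chain ending in an amine on this oxygen would read.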